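Removing one methoxy from the shared core of compound 1

A few compounds are considered here, and "the series" means these few. Any claim that something is new, unique, unknown or untested is made for them only; others in the source may bear on it.

Compound 1 `COc1cc(-c2cc(/C=C/C(=O)c3ccc(N)cc3)[nH]n2)cc(OC)c1OC` is tested in a functional assay on TK-10 cells (Homo sapiens) for inhibition, read by sulforhodamine B assay, with a stated time of 48 h (on this read-out higher numbers stand for lower toxicity in this test and lower numbers for higher toxicity in this test), where compound 1 gives 51600 nM. Compound 2 `COc1ccc(-c2cc(/C=C/C(=O)c3ccc(OC)c(OC)c3)[nH]n2)cc1` gives 8780 nM in this assay. Among the measured compounds shown here, of the two numbers, compound 1 holds the higher one and compound 2 the lower, a gap beyond the scatter; compound 2 differs from compound 1 in more than one place, so no single step links them. Compound 3 `COc1cc(-c2cc(/C=C/C(=O)c3ccc(Cl)c(Cl)c3)[nH]n2)cc(OC)c1OC` gives > 100000 nM, which is a limit of this assay and not a number. Going by these compounds, from compound 1 the change an at least 1.9-fold higher number from compound 1 to compound 3 (0.28 log units; that floor lies within the scatter) rests on (the limit of > 100000 nM in this assay, at which 1 of the 3 values shown sits), so its true size is unknown.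

Compound 4 `COc1ccc(-c2cc(/C=C/C(=O)c3ccc(N)cc3)[nH]n2)cc1OC` is not yet measured. It differs from compound 1 by hydrogen in place of methoxy on an aromatic carbon. For the measured compounds named here, the one measured step sits on the ring bonded to the carbonyl, not on the ring carrying the methoxy groups, so no measured step bears directly on this change. The number for compound 4 is therefore expected to stay within the scatter of compound 1, giving an estimated 1.3-fold lower number from compound 1 to compound 4 (0.11 log units; within the scatter). Compound 4 is estimated at 40000 nM, within 15000 nM to 100000 nM.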

Compound 4, concentration lethal to 50% of the cells: 48700 nM
Compound 4: middle estimate off by 1.2-fold (0.09 log units), on the low side, within the range that was stated.
By their numbers in this assay, from the lowest: compound 2; then compounds 4 and 1 (each within the scatter of the next). At a limit, above all of these: compound 3.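

In this assay the step of a 1.1-fold lower number from compound 1 to compound 4 (0.03 log units; within the scatter) shows that this methoxy can give way to hydrogen with no change beyond the scatter. Among the compounds shown here, the only earlier step, to compound 3, lay on the ring bonded to the carbonyl and rested on a limit, so this is the first step of readable size on the ring carrying the methoxy groups. Nothing measured here explains why the number holds at this position.

Going by these compounds, whether a larger or different group on this aromatic carbon, such as ethoxy, hydroxyl or fluorine, would also leave the number in place remains open. So does whether removing this methoxy would do the same with the 3,4-dichlorophenyl of compound 3 in place of the 4-aminophenyl, or whether the other two methoxy groups can be replaced by hydrogen as well.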